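Swapping an aryl group on the amide nitrogen of a weak compound

The compounds below may be only part of what the source reports. "The series", "measured", "known", "first", "only" and "open" are said of these compounds alone.

Compound 1 `Cc1ccc(OCC(=O)N(Cc2cccs2)c2cnn(C)c2)cc1` gives 63000 nM.
Compound 2 `CCN(Cc1ccc(C)s1)C(=O)COc1ccc(C)cc1` gives 178 nM.
Compound 3 `CCN(Cc1cccs1)C(=O)c1cc2cc(C)ccc2o1` gives 120 nM.

Of the compounds shown here, three have been measured in an assay on HEK293 cells for agonist activity at transient receptor potential cation channel subfamily M member 8 (Homo sapiens), read by fluorescence and calcium flux, with a stated time of 15 min; a lower number here means that less compound is needed, a higher number that more compound is needed for the effect. Compound 1 stands at the high end of these numbers: its value lies far beyond the scatter from that of compound 2, and further still from that of compound 3. For the measured compounds named here, compound 2 and compound 3 both carry an ethyl group on the amide nitrogen, where compound 1 carries an aromatic ring, but no single-change comparison exists between compound 1 and either of them, so what their values show is only that compound 1 needs far more material for the same effect.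

Compound 4 `Cc1ccc(OCC(=O)N(Cc2cccs2)c2ncccn2)cc1` is the next compound. It differs from compound 1 in one place: pyrimidin-2-yl in place of 1-methyl-1H-pyrazol-4-yl on an amide-type nitrogen. The heavy-atom count and the count of donors and acceptors are unchanged; only the ring size and the attachment change. Nothing in the measured set tests such a swap, so the direction of the step is uncertain. The expected step from compound 1 to compound 4 in this assay is a 1.6-fold lower number from compound 1 to compound 4 (0.20 log units; within the scatter), small and within the scatter. Compound 4 is therefore estimated at 40000 nM, with a range from 10000 nM to 200000 nM.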

Compound 4, half-maximal effective concentration: 3700 nM
Compound 4: the middle estimate sits 11-fold (1.03 log units) above what was measured, outside the stated range (below it).
By their numbers in this assay, from the lowest: compounds 3 and 2 (each within the scatter of the next); then compound 4; then compound 1.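

In this assay, for the compounds shown here, the group on this amide-type nitrogen proves to be a strong handle on the number, with a 17-fold lower number from compound 1 to compound 4 (1.23 log units; beyond the scatter), the first single-change step. The two groups match in heavy atoms, carbon, nitrogen, hydrogen-bond donors and acceptors, and neither carries a net charge, so this large step comes with no change in any of those counts, only with a six-membered aromatic ring taking the place of a five-membered one and a different attachment. No measurement at hand accounts for a step of this size.

The compounds shown leave open whether the step follows the ring size, the placement of the ring nitrogens, or the loss of the methyl group of the 1-methyl-1H-pyrazol-4-yl group, and a phenyl, pyridin-2-yl or pyrimidin-5-yl group on the same nitrogen would begin to separate these readings. They also leave open how a saturated ring such as piperidin-4-yl would stand on this nitrogen with the rest of compound 1 kept, and so whether an aromatic ring is needed there at all.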